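Fluoro on the core of compound 1

The compounds below may be only part of what the source reports. "The series", "measured", "known", "first", "only" and "open" are said of these compounds alone.

Measured in a functional assay on MCF7 cells (Homo sapiens) for antiproliferative activity; on this read-out lower numbers stand for stronger inhibition of growth and higher numbers for weaker inhibition of growth:
- compound 1 `Oc1ccc(-c2nc3ccccc3s2)cc1O` gives 2190 nM
- compound 2 `COc1ccc(-c2nc3cc(F)ccc3s2)cc1` gives 490 nM
- compound 3 `COc1ccc(-c2nc3cc(F)ccc3s2)cc1Cl` gives 760 nM

Compound 1 stands highest of the three, beyond the scatter from both others. Compound 4 `Oc1ccc(-c2nc3cc(F)ccc3s2)cc1O` is compound 1 with one change: fluoro in place of hydrogen on an aromatic carbon. Going by the values given here, no measured step isolates this change. Among the compounds with values here, the only step available, a 1.6-fold higher number from compound 2 to compound 3 (0.19 log units; within the scatter), is a chloro change and gives little guidance. Compound 2 at 490 nM and compound 3 at 760 nM carry fluoro, but they also differ from compound 1 elsewhere. A small move toward a lower number is therefore expected in this assay, possibly none beyond the scatter. The expected step is a 1.8-fold lower number from compound 1 to compound 4 (0.26 log units; within the scatter). For compound 4 the estimated value is 1200 nM, with an expected range of 350 nM to 4000 nM.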

Compound 4, concentration for 50% growth inhibition: 720 nM
The estimate for compound 4 lay 1.7-fold (0.22 log units) above the measured number; low and high end bracket the measured number.
By their numbers in this assay, from the lowest: compounds 2, 4 and 3 (each within the scatter of the next); then compound 1.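

In this assay, fluoro in place of hydrogen on an aromatic carbon of the core of compound 1 gives a 3.0-fold lower number from compound 1 to compound 4 (0.48 log units; beyond the scatter) and so lowers the number beyond the scatter. Going by these compounds alone, this is the first measured step to isolate fluoro at this place, meta to a fused ring and para to a fused ring, with the rest of compound 1 unchanged. Nothing measured here explains the step.

The compounds shown leave open whether an amine or trifluoromethyl on this carbon would move the number as far. On these data alone, it also remains open whether fluoro has the same effect without the hydroxy groups of compound 4.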